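Swapping the Aryl Ether of Compound 1 for Compound 4

A few compounds are considered here, and "the series" means these few. Any claim that something is new, unique, unknown or untested is made for them only; others in the source may bear on it.

Compound 1 `C=C1CC[C@H]2[C@@](C)(CCC(=O)[C@@]2(C)COC(C)=O)[C@@H]1C/C=C1/C(=O)OC[C@H]1Oc1c(Cl)cc(Cl)c2cccnc12` was examined in an ADME assay on SNB-19 cells (Homo sapiens) for cytotoxicity, read by MTT assay, with a stated time of 24 h; on this read-out higher numbers stand for lower toxicity in this test and lower numbers for higher toxicity in this test. In that test compound 1 gives only a limit, > 100000 nM. Compound 3 `C=C1CC[C@H]2[C@@](C)(CCC(=O)[C@@]2(C)COC(C)=O)[C@@H]1C/C=C1/C(=O)OC[C@@H]1Oc1c(Cl)cc(Cl)c2cccnc12`, which has the same atoms and bonds and differs only in configuration as drawn, gives 72000 nM, and compound 2 `C=C1CC[C@@H]2[C@](C)(COC(C)=O)[C@H](O)CC[C@@]2(C)[C@@H]1C/C=C1/C(=O)OC[C@@H]1Oc1c(Cl)cc(Cl)c2cccnc12` gives 39300 nM. Among the measured compounds shown here, the only measured step that bears on the question is an at least 1.3-fold lower number from compound 1 to compound 3 (0.14 log units; that floor lies within the scatter), and its size rests on the limit of > 100000 nM in this assay, at which 1 of the 3 values shown sits, together with the fact that compounds 1 and 3 differ only in the configuration as drawn. Compound 4 `C=C1CC[C@H]2[C@@](C)(CCC(=O)[C@@]2(C)COC(C)=O)[C@@H]1C/C=C1/C(=O)OC[C@H]1Oc1cccc2ccc(C)nc12` differs from compound 1 by 2-methylquinolin-8-yl in place of 5,7-dichloroquinolin-8-yl on an oxygen on a saturated carbon. For the measured compounds named here, no measured step covers a change of this kind, so no shift beyond the scatter is expected for a number no higher from compound 1 to compound 4 (the limit leaves the size open). Compound 4 is therefore estimated at 100000 nM, within 35000 nM to 300000 nM.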

Compound 4, half-maximal cytotoxic concentration: > 100000 nM
Compound 4: no number, only a limit; the forecaster's own chance of this, stated with the estimate: 55%; the middle value lies on the limit itself.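

No step can be read from compound 1 to compound 4 in this assay, because both compounds give only a limit: the limit of > 100000 nM in this assay, at which 2 of the 4 values shown sit. The compounds shown leave open how far 2-methylquinolin-8-yl in place of 5,7-dichloroquinolin-8-yl moves the number.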